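From phenylcarbamoyl to a methylated pyrazolylamino group

This account rests on a few compounds, and the source may have more. Where it says the series, first, only, none or still open, it means among the compounds named here.

Among the measured compounds shown here, in a physicochemical assay for lipophilicity, using the shake flask method, in phosphate buffer, measured as octanol-water partition, with a stated time of 30 min, at pH 7.4 (a lower number here means a more polar compound, a higher number a more lipophilic compound), compound 1 `O=C(Nc1ccccc1)c1cnc(NCc2c(F)ccc3c2CCO3)n2cnnc12` gives 4.1 and stands highest of the two numbers so far. Compound 2 `Cn1nccc1-c1cnc(NCc2c(F)ccc3c2CCO3)c2cn[nH]c(=O)c12` gives 2.6 as the nearest value, lower and beyond the scatter. For the measured compounds named here, these two compounds differ in more than one place, so no single-change step is available as a guide.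

Compound 3 `CN(c1ccn(C)n1)c1cnc(NCc2c(F)ccc3c2CCO3)n2cnnc12` keeps the core of compound 1 but has methyl(1-methyl-1H-pyrazol-3-yl)amino in place of phenylcarbamoyl on an aromatic carbon. A six-membered aromatic ring of carbon only leaves and a five-membered aromatic ring with 2 hetero atoms enters.

Compound 2 at 2.6 is the only lower reference point, so this expectation is loose. The step expected in this assay is a number 0.90 log units lower from compound 1 to compound 3 (beyond the scatter) and it is estimated to be downward and beyond the scatter. The expected value for compound 3 is 3.2 (estimated range 2.7 to 3.7).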

Compound 3, distribution coefficient: 1.8
Beside the measured number, compound 3's estimate is 1.40 log units above it; measured number outside the range, below it.
By their numbers in this assay, from the lowest: compound 3; then compound 2; then compound 1.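

In this assay, among the compounds shown here, methyl(1-methyl-1H-pyrazol-3-yl)amino in place of phenylcarbamoyl gives a number 2.30 log units lower from compound 1 to compound 3 (beyond the scatter), the first single-place step, and it shows that this aromatic carbon on the shared core can carry a large change in the distribution coefficient. The change is compound in itself: the six-membered aromatic ring of carbon only gives way to a five-membered aromatic ring with 2 hetero atoms, while the carbonyl and the hydrogen-bond donor leave, so the step belongs to the whole replacement and not to any one of these features. Nothing available ties the step to a cause.

Still open, going by these compounds, is how the step divides between the ring and the link that joins it to the core; a methyl(phenyl)amino group at this position would separate the two. Also open, on these data alone, is where a non-aromatic group, such as morpholine or a primary amine, would fall on this core.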